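A few compounds are considered here, and "the series" means these few. Any claim that something is new, unique, unknown or untested is made for them only; others in the source may bear on it.

Measured compounds:
- compound 1 `Cn1c(=O)c(=O)n(C2CCCC2)c2nc(N/N=C/c3ccccc3)ncc21`: 48200 nM
- compound 2 `Cn1c(=O)c(=O)n(C2CCCC2)c2nc(N/N=C/c3ccc(S(C)(=O)=O)cc3)ncc21`: 26600 nM
- compound 3 `Cc1cc(C)c(/C=N/Nc2ncc3c(n2)n(C2CCCC2)c(=O)c(=O)n3C)c(C)c1`: 13900 nM

In a functional assay on PC-3 cells (Homo sapiens) for antiproliferative activity, read by MTT assay (on this read-out lower numbers stand for stronger inhibition and higher numbers for weaker inhibition), compound 3 gives the lowest number of the three, beyond the scatter only against compound 1. Compound 4 `CSc1ccc(/C=N/Nc2ncc3c(n2)n(C2CCCC2)c(=O)c(=O)n3C)cc1` differs from it in one place: 4-(methylsulfanyl)phenyl in place of 2,4,6-trimethylphenyl on a carbon with a double bond to nitrogen. For the measured compounds named here, two measured steps bear on this. The step of a 3.5-fold lower number from compound 1 to compound 3 (0.54 log units; beyond the scatter) shows a modest gain on going to the trimethylated ring, and the step of a 1.9-fold lower number from compound 2 to compound 3 (0.28 log units; within the scatter) is within the scatter. Undoing the trimethyl substitution therefore points toward a higher number, and the new group resembles neither the bare phenyl of compound 1 nor the methylsulfonyl of compound 2 closely. A step of a 1.8-fold higher number from compound 3 to compound 4 (0.25 log units; within the scatter) is expected, so compound 4 is estimated at 25000 nM, between 10000 nM and 60000 nM.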

Compound 4, half-maximal inhibitory concentration: 21000 nM
Estimate against measurement, compound 4: 1.2-fold (0.08 log units) above, within the range that was stated.
By their numbers in this assay, from the lowest: compounds 3, 4, 2 and 1 (each within the scatter of the next, the first and the last beyond it).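

In this assay, methylsulfanyl in place of hydrogen on the ring gives a 2.3-fold lower number from compound 1 to compound 4 (0.36 log units; beyond the scatter) and so keeps a modest gain over the bare phenyl, which shows that the three methyl groups of compound 3 are not required for one. The methylsulfanyl ring cannot be told apart from the trimethylated ring, with a 1.5-fold higher number from compound 3 to compound 4 (0.18 log units; within the scatter) as the step, or from the methylsulfonyl ring, with a 1.3-fold lower number from compound 2 to compound 4 (0.10 log units; within the scatter) as the step. Nothing measured here explains these steps. Going by these compounds, whether an amine or a carboxylic acid on this ring would shift the number remains open, as does the effect of a longer chain on the sulfur.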